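Trifluoromethyl loss from compound 1 to compound 4

The source may hold more compounds than are shown below. What is called first, only, known or untested is meant among the compounds shown, and "the series" means these compounds.

In a functional assay on B16-BL6 cells (Mus musculus) for cytotoxicity, read by MTT assay, with a stated time of 48 h (a lower number here means a stronger inhibitor, a higher number a weaker inhibitor), compound 1 `CNC(=O)c1ccc(Sc2cccc(NC(=S)Nc3ccc(Cl)c(C(F)(F)F)c3)c2)nc1` gives 19800 nM, the lower of the two actual numbers in the series. Compound 3 `CNC(=O)c1ccc(Sc2ccc(NC(=S)Nc3ccc(Cl)cc3)cc2)nc1` gives 69300 nM, a higher number, and the gap between the two lies beyond the scatter. Compound 2 `CNC(=O)c1ccc(Sc2ccc(NC(=S)Nc3cccc(C)c3)cc2)nc1` gives > 100000 nM, which is a limit of the assay and not a number.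

Compound 4 `CNC(=O)c1ccc(Sc2cccc(NC(=S)Nc3ccc(Cl)cc3)c2)nc1` is not yet measured in this assay. It differs from compound 1 by one change: hydrogen in place of trifluoromethyl on an aromatic carbon. In short, hydrogen takes the place of trifluoromethyl on an aromatic carbon.

Going by the values given here, the only measured step is an at least 1.4-fold lower number from compound 2 to compound 3 (0.15 log units; that floor lies within the scatter). It concerns a different replacement and rests on a limit, so it gives no size for this change. The closest guide is compound 3, which carries no trifluoromethyl and gives 69300 nM. However, compound 3 also differs from compound 1 elsewhere, so that gap is only a loose guide. A moderate move towards a higher number, and so a weaker inhibitor, is expected, although no change beyond the scatter remains possible. The expected step is a 2.3-fold higher number from compound 1 to compound 4 (0.36 log units; beyond the scatter). For compound 4 the estimated value is 45000 nM. The expected range for compound 4 runs from 18000 nM to 100000 nM.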

Compound 4, half-maximal inhibitory concentration: 67500 nM
Estimate against measurement, compound 4: 1.5-fold (0.18 log units) below; measured number inside the range.
By their numbers in this assay, from the lowest: compound 1; then compounds 4 and 3 (each within the scatter of the next). At a limit, above all of these: compound 2.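

In this assay, going by these compounds alone, the one-place replacement of trifluoromethyl by hydrogen, ortho to a chloro group, gives a 3.4-fold higher number from compound 1 to compound 4 (0.53 log units; beyond the scatter), so this position now has a step of its own, beyond the scatter, where the earlier compounds offered only a gap confounded by a second difference. Compound 4 and compound 3 lie within the scatter of each other, so the two compounds without trifluoromethyl cannot be told apart in this assay, and in this pair the place where the two compounds differ shows no separate effect. Nothing shown here gives a measured property that would account for the step from trifluoromethyl to hydrogen.

Only trifluoromethyl and hydrogen are shown at this aromatic carbon, so it remains open whether a methyl group, a nitrile or a carboxylic acid there would stay with compound 1 or with compound 4. Within the data shown here, it also remains open whether the same replacement would give a step of similar size on the core of compound 3, as this rests on the single pair of compound 1 and compound 4.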